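Compound 2 and the Step to Compound 4

The source may report more compounds than this note shows. Statements on the series, on what has been measured and on what is new or still open speak of the compounds shown alone.

Values measured in an ADME assay on microsomes from liver (Rattus norvegicus) for metabolic stability; on this read-out higher numbers stand for a longer-lived compound and lower numbers for a shorter-lived compound:
- Compound 1 `CCC(CC)(c1nnc[nH]1)c1ccc(-c2ccc3cc(F)cc(F)c3c2)[nH]c1=O`: 1.26 h
- Compound 2 `CC(C)C(Cc1ncc[nH]1)c1ccc(-c2ccc3cccc(F)c3c2)[nH]c1=O`: < 0.0667 h
- Compound 3 `CCn1ncc2c(F)cc(-c3ccc(C(CC)(CC)c4nncn4C)c(=O)[nH]3)cc21`: > 3 h

Compound 2 stands at the low end of these three readings. Its entry of < 0.0667 h is a limit of the assay and not a number. Compound 3 is also reported only as a limit, > 3 h.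

Compound 4 `CC(C)C(c1nnc[nH]1)c1ccc(-c2ccc3cccc(F)c3c2)[nH]c1=O` has not yet been measured. It differs from compound 2 in one place: 4H-1,2,4-triazol-3-yl in place of (1H-imidazol-2-yl)methyl on a saturated chain carbon bound to an aromatic carbon and a saturated chain carbon. Among the compounds with values here, no measured pair isolates this change, so its size can only be expected. Compound 1, which also carries the 4H-1,2,4-triazol-3-yl group, gives 1.26 h. On that basis, a rise beyond the usual scatter in this assay is expected for compound 4. The estimated change is an at least 5.9-fold higher number from compound 2 to compound 4 (0.77 log units; beyond the scatter). For compound 4 the expected half-life is 0.4 h, with an estimated range from 0.1 h to 1.5 h.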

Compound 4, half-life: 0.552 h
Beside the measured number, compound 4's estimate is 1.4-fold (0.14 log units) below it; the range from low to high includes it.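

In this assay, placing 4H-1,2,4-triazol-3-yl in place of (1H-imidazol-2-yl)methyl on a saturated chain carbon bound to an aromatic carbon and a saturated chain carbon gives an at least 8.2-fold higher number from compound 2 to compound 4 (0.91 log units; beyond the scatter). This is the first pair among the compounds shown that differs in one place, and it shows that the half-life depends on the group held at this carbon, by a margin beyond the usual scatter. The step has only a lower bound, and its full size stays unknown, since compound 2 is reported as a limit and not as a number: the limit of < 0.0667 h in this assay, at which 1 of the 4 values shown sits.

The compounds shown leave open whether the step follows the change of ring or the loss of the methyl link, since both change together. A 1H-imidazol-2-yl group set directly on this carbon, or a (4H-1,2,4-triazol-3-yl)methyl group, would separate the two.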